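The compounds below may be only part of what the source reports. "The series", "measured", "known", "first", "only" and "open" are said of these compounds alone.

Working notes on the series in an assay on CHO cells for displacement of a labelled ligand from adenosine receptor A3 (Homo sapiens), read by scintillation counting, with a stated time of 3 h; on this read-out higher numbers stand for weaker inhibition and lower numbers for stronger inhibition.

Three compounds share the core. Compound 1 `Cn1c(-c2ccc(F)cc2)nc2c(NC3CCCC3)ncnc21` gives 1140 nM in this assay. Compound 2 `Cn1c(-c2cccc(Cl)c2)nc2c(NC3CCCC3)ncnc21` gives 514 nM, and the step of a 2.2-fold lower number from compound 1 to compound 2 (0.35 log units; beyond the scatter) is a modest one. Compound 3 `Cn1c(-c2ccc(C(=O)O)cc2)nc2c(NC3CCCC3)ncnc21` gives 25700 nM, the highest of the three numbers; its nearest neighbour is compound 1, and the step of a 23-fold higher number from compound 1 to compound 3 (1.35 log units; beyond the scatter) is large, while compound 2 lies still further from it.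

The next compound, compound 4 `Cc1ccc(-c2nc3c(NC4CCCC4)ncnc3n2C)cc1`, differs from compound 3 by methyl in place of carboxy on an aromatic carbon. Of the measured steps, the one that bears directly on this change is a 23-fold higher number from compound 1 to compound 3 (1.35 log units; beyond the scatter), since it shows what the carboxy group did when it entered in place of a small substituent at the same position of the phenyl ring. Removing the carboxy group in favour of methyl is expected to undo most of that rise. The step of a 2.2-fold lower number from compound 1 to compound 2 (0.35 log units; beyond the scatter) concerns a different position and a different group and offers only a weak hint that small uncharged substituents on this ring give numbers in the same region as compound 1.

For compound 4 a large downward step is therefore expected, a 32-fold lower number from compound 3 to compound 4 (1.51 log units; beyond the scatter), bringing it close to compound 1. The estimate for compound 4 in this assay is 800 nM, with a range from 200 nM to 3500 nM.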

Compound 4, inhibition constant: 480 nM
For compound 4 the middle estimate is 1.7-fold (0.22 log units) above the measured one, and the stated range covers the measured number.
By their numbers in this assay, from the lowest: compounds 4 and 2 (each within the scatter of the next); then compound 1; then compound 3.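

Methyl in place of carboxy on an aromatic carbon, para to a large group, gives a 54-fold lower number from compound 3 to compound 4 (1.73 log units; beyond the scatter) in this assay and so shows that the high number of compound 3 does not carry over to a second small group at this place. Within the data shown here, until now fluoro was the only such comparison for carboxy, and methyl in place of fluoro now gives a 2.4-fold lower number from compound 1 to compound 4 (0.38 log units; beyond the scatter) so the position also separates two small groups, by a modest step rather than a large one. The comparison with the other substituted ring gives a 1.1-fold lower number from compound 2 to compound 4 (0.03 log units; within the scatter) which means that 4-methylphenyl and 3-chlorophenyl cannot be told apart here, although both the group and its place differ.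

Nothing measured on these compounds accounts for any of these steps.

The compounds shown do not separate the effect of the group from that of its place, a question that 4-chlorophenyl and 3-methylphenyl would address. They also leave open how an amine, a methoxy group or a longer chain such as propyl would read at the position para to a large group, and whether a methyl ester would share the high number of the carboxylic acid.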